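Replacing 4-methylphenyl with 5-methylthiophen-2-yl: working notes

The compounds below may be only part of what the source reports. "The series", "measured", "known", "first", "only" and "open" are said of these compounds alone.

Measured so far in a functional assay on HeLa cells (Homo sapiens) for cytotoxicity, read by MTT assay, with stated times of 3 h and 24 h (on this read-out lower numbers stand for stronger inhibition and higher numbers for weaker inhibition), for two compounds:
- compound 1 `COc1ccc2c(c1)CCc1c(-c3ccccc3)c3n(c1-2)[B-](F)(F)[N+]1=C(c2ccc(C)s2)C(Br)=C(c2ccccc2)C1=N3` gives 22600 nM
- compound 2 `COc1ccc2c(c1)CCc1c(-c3ccccc3)c3n(c1-2)[B-](F)(F)[N+]1=C(c2ccc(C)cc2)C(I)=C(c2ccccc2)C1=N3` gives 110 nM

Compound 2 holds the lower of the two numbers, and its gap to compound 1 lies beyond the scatter. The next compound is compound 3 `COc1ccc2c(c1)CCc1c(-c3ccccc3)c3n(c1-2)[B-](F)(F)[N+]1=C(c2ccc(C)s2)C(I)=C(c2ccccc2)C1=N3` which differs from compound 2 by 5-methylthiophen-2-yl in place of 4-methylphenyl on a carbon with a double bond to nitrogen and keeps the iodo group.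

Going by the values given here, no measured pair in this assay shows this exchange alone, so any step size here is a judgment. A moderate step towards a higher number, meaning weaker inhibition, is expected, probably beyond the scatter. Among the compounds with values here, compound 1 is the only measured compound carrying 5-methylthiophen-2-yl. Compound 1 gives 22600 nM in this read-out. That single value is weak evidence, so the expectation stays nearer to compound 2 at 110 nM on the same read-out. The expected change is a 3.6-fold higher number from compound 2 to compound 3 (0.56 log units; beyond the scatter) on this estimate. The estimate for compound 3 is 400 nM within an expected range of 70 nM to 5000 nM for now.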

Compound 3, half-maximal inhibitory concentration: 12300 nM
Beside the measured number, compound 3's estimate is 31-fold (1.49 log units) below it, outside the stated range (above it).
By their numbers in this assay, from the lowest: compound 2; then compounds 3 and 1 (each within the scatter of the next).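

In this assay, 5-methylthiophen-2-yl in place of 4-methylphenyl on a carbon with a double bond to nitrogen, with the iodo group kept, gives a 110-fold higher number from compound 2 to compound 3 (2.05 log units; beyond the scatter), so this single exchange is a large step and this position does not tolerate the two groups alike. With 5-methylthiophen-2-yl held constant, iodo in place of bromo on a double-bonded ring carbon gives a 1.8-fold lower number from compound 1 to compound 3 (0.26 log units; within the scatter), which stays within the scatter; of the two places in which compound 1 and compound 2 differ, only the aryl exchange has so far been read as a large step. No measurement on hand bears on why the 4-methylphenyl compound stands apart from its 5-methylthiophen-2-yl partner.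

From the compounds shown here alone, the halogen exchange has been read only with 5-methylthiophen-2-yl present, so whether iodo and bromo also sit within the scatter alongside 4-methylphenyl remains open. The compounds shown also leave open whether the large step belongs to the sulfur-containing ring itself or to this particular group, a question that an unsubstituted phenyl, a 4-methoxyphenyl or an unsubstituted thiophen-2-yl at the same carbon would address.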